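Chain extension on the triazole nitrogen substituent

The source may hold more compounds than are shown below. What is called first, only, known or untested is meant among the compounds shown, and "the series" means these compounds.

Measured compounds:
- compound 1, `CCn1nc(C(=O)N[C@H]2COc3ccccc3N(C)C2=S)nc1Cc1ccccc1`, 17 nM in a functional assay on HT-29 cells (Homo sapiens) for inhibition, read by luminescence and CellTiter-Glo, with a stated time of 24 h; a lower number here means that less compound is needed, a higher number that more compound is needed for the effect
- compound 2, `CCCn1nc(C(=O)N[C@H]2COc3ccccc3N(C)C2=S)nc1Cc1ccccc1`, 288 nM in this assay
- compound 3, `CN1C(=S)[C@@H](NC(=O)c2nc(Cc3ccccc3)n(CCC(F)(F)F)n2)COc2ccccc21`, 1550 nM in this assay

Compound 2 holds the second highest number of the three in this assay; compound 3 lies nearer to it, with a 5.4-fold higher number from compound 2 to compound 3 (0.73 log units; beyond the scatter), and compound 1 lies furthest, with a 17-fold higher number from compound 1 to compound 2 (1.23 log units; beyond the scatter). Compound 4, `CN1C(=S)[C@@H](NC(=O)c2nc(Cc3ccccc3)n(CCCCC#N)n2)COc2ccccc21`, is not yet measured. It differs from compound 2 by cyanomethyl in place of hydrogen on a saturated chain carbon, three bonds along the chain from an aromatic nitrogen.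

The measured steps all change the same chain on the shared core. Going from compound 1 to compound 2 lengthened that chain by one carbon and gave a 17-fold higher number from compound 1 to compound 2 (1.23 log units; beyond the scatter). Going from compound 1 to compound 3 gave a 91-fold higher number from compound 1 to compound 3 (1.96 log units; beyond the scatter), and from compound 2 to compound 3 gave a 5.4-fold higher number from compound 2 to compound 3 (0.73 log units; beyond the scatter). Both changes away from compound 1 raised the number, and the larger group raised it more. Among the measured compounds shown here, the change from compound 2 to compound 4 also lengthens the chain and adds a heavy-atom group at its end, so a higher number is expected in this assay, though no measured step carries a nitrile and the size is uncertain.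

Compound 4 is therefore estimated at 1500 nM in this assay, within 300 nM to 7000 nM, which would be an expected step of a 5.2-fold higher number from compound 2 to compound 4 (0.72 log units; beyond the scatter).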

Compound 4, half-maximal effective concentration: 2680 nM
Compound 4: the middle estimate sits 1.8-fold (0.25 log units) below what was measured; measured number inside the range.
By their numbers in this assay, from the lowest: compound 1; then compound 2; then compounds 3 and 4 (each within the scatter of the next).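

In this assay, the 4-cyanobutyl chain in place of the propyl chain raises the number further (a 9.3-fold higher number from compound 2 to compound 4 (0.97 log units; beyond the scatter)), and the distance from the ethyl chain is large (a 160-fold higher number from compound 1 to compound 4 (2.20 log units; beyond the scatter)), so a chain ending in a nitrile does not recover what is lost on leaving ethyl. All three chains beyond ethyl now give higher numbers than compound 1, and none of the four compounds goes against this. The two chains with different end groups cannot be told apart at this position (a 1.7-fold higher number from compound 3 to compound 4 (0.24 log units; within the scatter)), and nothing at hand bears on the reason for any of these steps.

From the compounds shown here alone, what remains open is whether the higher number in compound 4 follows from chain length or from the nitrile, which a plain butyl or pentyl chain would help to separate. Also open, going by these compounds, is how this position responds to a methyl group or a hydrogen in place of ethyl, or to a chain ending in an amine, a carboxylic acid or a hydroxyl group.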